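The source may hold more compounds than are shown below. What is called first, only, known or untested is meant among the compounds shown, and "the series" means these compounds.

The measured compounds, in a functional assay on U-251 cells (Homo sapiens) for antiproliferative activity, read by MTT assay, with a stated time of 72 h; on this read-out lower numbers stand for stronger inhibition and higher numbers for weaker inhibition:

Compound 1, `CS(=O)(=O)c1ccc(C(=O)Nc2ccc(Cl)c(-c3nnc4c(Cl)cccn34)c2)cc1`: in this assay compound 1 gives > 100000 nM, which is a limit of the assay and not a number.
Compound 2, `O=C(Nc1ccc(Cl)c(-c2nnc3c(Cl)cccn23)c1)c1ccon1`: in this assay compound 2 gives > 100000 nM, again a limit.
Compound 3, `O=C(Nc1ccc(Cl)c(-c2nnc3c(Cl)cccn23)c1)c1c(F)cccc1Cl`: in this assay compound 3 gives > 100000 nM, likewise a limit.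

Compound 3 thus stands at the limit shared by every value shown; the three compounds sit at the limit of > 100000 nM in this assay, at which 3 of the 3 values shown sit, and none of them yields a readable number. The steps among them, a step that the two limits leave unreadable from compound 1 to compound 2, a step that the two limits leave unreadable from compound 1 to compound 3 and a step that the two limits leave unreadable from compound 2 to compound 3, therefore have no readable size. Nothing in these data separates one group on the carbonyl carbon from another.

Compound 4, `CS(=O)(=O)c1cccc(C(=O)Nc2ccc(Cl)c(-c3nnc4c(Cl)cccn34)c2)c1`, has not yet been measured. It differs from compound 3 in one place: 3-(methylsulfonyl)phenyl in place of 2-chloro-6-fluorophenyl on a carbonyl carbon. Among the compounds with values here, the steps that bear on this change are the three just named, and all of them are unreadable, so no direction can be drawn from them. The closest point of comparison is compound 1, which carries a methylsulfonyl group on the same ring and sits at the limit.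

On that basis compound 4 is expected to give about 100000 nM, with a range from 30000 nM to 300000 nM, most likely reported only as a limit. This expectation amounts to a step of a number no higher from compound 3 to compound 4 (the limit leaves the size open).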

Compound 4, half-maximal inhibitory concentration: > 100000 nM
Compound 4: no number, only a limit; the forecaster's own chance of this, stated with the estimate: 85%; the middle value sits exactly at the limit.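

In this assay compound 4 gives > 100000 nM, which is a limit and not a number. No step linking compound 4 to compound 1, compound 2 or compound 3 can be read, and the series stays where it was: the limit of > 100000 nM in this assay, at which 4 of the 4 values shown sit.

The compounds shown leave open whether any group on the carbonyl carbon would give a readable number in this assay.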